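The source may report more compounds than this note shows. Statements on the series, on what has been measured and on what is new or still open speak of the compounds shown alone.

Series notes. Compound 1 `Cc1ccc(C2=NN(c3nc(-c4ccccc4)cs3)C(c3ccc(F)cc3)C2)s1` is the parent with an unsubstituted phenyl. In a functional assay on A549 cells (Homo sapiens) for antiproliferative activity, read by XTT assay, with a stated time of 24 h (on this read-out lower numbers stand for stronger inhibition and higher numbers for weaker inhibition), compound 1 gives > 500 ug/mL, a limit of the assay and not a number. Compound 2 `Cc1ccc(C2=NN(c3nc(-c4ccc(Br)cc4)cs3)C(c3ccc(F)cc3)C2)s1` carries bromo in place of hydrogen on an aromatic carbon; in this assay compound 2 gives > 500 ug/mL, again a limit rather than a number. The step that the two limits leave unreadable from compound 1 to compound 2 is therefore unreadable. Among the measured compounds shown here, compound 3 `Cc1ccc(C2=NN(c3nc(-c4ccc(C#N)cc4)cs3)C(c3ccc(F)cc3)C2)s1` carries cyano in place of hydrogen on an aromatic carbon, and in this assay compound 3 gives 322 ug/mL, the only number in the set. Against both limits the cyano compound reads lower, an at least 1.5-fold lower number from compound 1 to compound 3 (0.19 log units; that floor lies within the scatter) and an at least 1.5-fold lower number from compound 2 to compound 3 (0.19 log units; that floor lies within the scatter), though each floor lies within the scatter. Compound 4 `Cc1ccc(C2=NN(c3nc(-c4ccc(Cl)cc4)cs3)C(c3ccc(F)cc3)C2)s1` differs from compound 3 by chloro in place of cyano on an aromatic carbon. For the measured compounds named here, no measured step covers this change directly; the nearest comparison is compound 2, whose bromo on an aromatic carbon leaves it at the limit of > 500 ug/mL in this assay, at which 2 of the 3 values shown sit, while the cyano of compound 3 gave the one readable number. The step of a 1.5-fold higher number from compound 3 to compound 4 (0.17 log units; within the scatter) is expected to run back towards that limit, a higher number in this assay if one is reported at all. Compound 4 is estimated at 480 ug/mL, with the range 250 ug/mL to 900 ug/mL, and a limit is the likelier report.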

Compound 4, half-maximal inhibitory concentration: > 500 ug/mL
Compound 4: no number, only a limit; the forecaster's own chance of this, stated with the estimate: 60%; middle value at least 1.0-fold (0.01 log units) from the limit.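

With chloro on this aromatic carbon, para to a large group, the 4-chlorophenyl compound reads the same way as the phenyl and 4-bromophenyl compounds, so in this assay the 4-cyanophenyl group of compound 3 remains the only one at this position with a readable number: the limit of > 500 ug/mL in this assay, at which 3 of the 4 values shown sit. The exchange of cyano for chloro reads as an at least 1.5-fold higher number from compound 3 to compound 4 (0.19 log units; that floor lies within the scatter), so this result alone does not establish a real loss on leaving the nitrile. The steps among compound 1, compound 2 and compound 4 run from limit to limit and cannot be read, so hydrogen, bromo and chloro cannot be ordered against one another.

Among the compounds shown here, it remains open whether the single reading of compound 3 is particular to the nitrile or would also appear with other groups on the same carbon, such as an amine, a carboxylic acid or a methoxy. With one number in the set and every other entry a limit, no trend across the substituents at this position can be stated.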